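The compounds below may be only part of what the source reports. "The series", "measured", "known", "first", "only" and "open" are said of these compounds alone.

Measured so far:
compound 1 `Cc1ccc(C)n1-c1ccc(-c2ccc(CCC(=O)O)cc2)c(C(=O)O)c1` gives 227000 nM
compound 2 `Cc1ccc(C)n1-c1ccc(-c2ccccc2)c(C(=O)O)c1` gives 290000 nM

Both numbers come from an ADME assay on MT2 cells (Homo sapiens) for cytotoxicity, read by XTT assay, with a stated time of 4 days; a lower number here means that less compound is tolerated, a higher number that more compound is tolerated. Compound 2 stands highest of the two numbers; its nearest neighbour is compound 1, and the step of a 1.3-fold higher number from compound 1 to compound 2 (0.11 log units; within the scatter) lies within the scatter. Compound 3 `Cc1ccc(C)n1-c1ccc(-c2ccc(C(=O)O)cc2)c(C(=O)O)c1` has not yet been measured in this assay. It differs from compound 2 by carboxy in place of hydrogen on an aromatic carbon. Going by the values given here, the one measured step that bears on this change is a 1.3-fold higher number from compound 1 to compound 2 (0.11 log units; within the scatter), in which a 2-carboxyethyl stood in place of hydrogen on the same aromatic carbon and the number hardly moved. On that basis the step from compound 2 to compound 3 in this assay is expected to stay within the scatter, with no direction to call. The estimate for compound 3 is 260000 nM, with a range from 120000 nM to 550000 nM. That estimate means an expected step of a 1.1-fold lower number from compound 2 to compound 3 (0.05 log units; within the scatter).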

Compound 3, half-maximal cytotoxic concentration: 355000 nM
For compound 3 the middle estimate is 1.4-fold (0.14 log units) below the measured one, within the range that was stated.
By their numbers in this assay, from the lowest: compounds 1, 2 and 3 (each within the scatter of the next).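

In this assay, carboxy on this aromatic carbon, para to a large group, gives a 1.2-fold higher number from compound 2 to compound 3 (0.09 log units; within the scatter), so a second group at this place leaves the number within the scatter of the compound carrying hydrogen. Going by these compounds alone, exchanging one such group for the other, a comparison the earlier compounds did not offer, gives a 1.6-fold higher number from compound 1 to compound 3 (0.19 log units; within the scatter), so shortening the chain from 2-carboxyethyl to carboxy also stays within the scatter, and all three compounds lie within the scatter of one another. Nothing available explains why the number stays so flat at this place.

On these data alone, both groups other than hydrogen end in a carboxylic acid, so it remains open whether an amine, a methyl ester or a longer chain on this carbon would stay as close. As far as these compounds go, it also remains open whether a change elsewhere on the shared core would move the number beyond the scatter.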